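The compounds below may be only part of what the source reports. "The series", "measured", "known", "first", "only" and "open" are said of these compounds alone.

Compound 1, `NNC(=O)c1c(NC(=O)NS(=O)(=O)c2ccccc2)sc2c1CCCCC2`: 4200 nM
Compound 2, `O=C(Nc1sc2c(c1C(=O)NNc1ccc(Cl)cc1)CCCCC2)NS(=O)(=O)c1ccccc1`: 8300 nM

In a functional assay on MCF7 cells (Homo sapiens) for inhibition, with a stated time of 48 h (a lower number here means a stronger inhibitor of growth, a higher number a weaker inhibitor of growth), compound 1 gives 4200 nM and compound 2 gives 8300 nM. The two share the same core and differ in one place, with 4-chlorophenyl in place of hydrogen on an amine nitrogen, and a 2.0-fold higher number from compound 1 to compound 2 (0.30 log units; within the scatter), so the two numbers cannot be told apart; compound 2 simply stands alongside compound 1.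

Compound 3, `O=C(Nc1sc2c(c1C(=O)N1CCN(c3ccccc3)CC1)CCCCC2)NS(=O)(=O)c1ccccc1`, has not yet been measured in this assay. It differs from compound 2 in a single spot: 4-phenylpiperazin-1-yl in place of ((4-chlorophenyl)amino)amino on a carbonyl carbon. Among the measured compounds shown here, this exchange goes further than the one between compound 1 and compound 2: the entering group carries no hydrogen-bond donor, whereas the leaving one does, and a non-aromatic ring comes in. For the measured compounds named here, the only measured step that bears on it is a 2.0-fold higher number from compound 1 to compound 2 (0.30 log units; within the scatter), which touched the same region and stayed within the scatter. Going by the values given here, no measured step shows what the loss of the donors does, so the expected step of a 1.1-fold higher number from compound 2 to compound 3 (0.04 log units; within the scatter) is a small one, within the scatter, with wide uncertainty. Compound 3 is therefore estimated at 9000 nM, in the range 2500 nM to 30000 nM.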

Compound 3, concentration for 50% growth inhibition: > 100000 nM
Compound 3: only a limit was reported; the forecaster's own chance of this, stated with the estimate: 15%; middle value at least 11-fold (1.04 log units) from the limit.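

In this assay, compound 3 has only a limit of the assay and not a number: the limit of > 100000 nM in this assay, at which 1 of the 3 values shown sits. Among the compounds shown here, this position, on a carbonyl carbon whose other neighbour is an aromatic carbon, had so far looked forgiving, since adding 4-chlorophenyl gave only a 2.0-fold higher number from compound 1 to compound 2 (0.30 log units; within the scatter), yet 4-phenylpiperazin-1-yl in place of ((4-chlorophenyl)amino)amino gives an at least 12-fold higher number from compound 2 to compound 3 (1.08 log units; beyond the scatter), and in place of aminoamino it gives an at least 23-fold higher number from compound 1 to compound 3 (1.37 log units; beyond the scatter). So the group on this carbonyl carbon can matter a great deal for growth inhibition in these cells, and a large group with an aromatic ring is not enough to keep the activity seen with compound 1 and compound 2, since the entering group has one too.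

The exchange alters several things at once, as the entering group has no hydrogen-bond donors and brings a non-aromatic ring, so the compounds shown cannot say which of these differences counts. On these data alone, a 4-phenylpiperidin-1-yl group or a simple anilino group on the same carbonyl carbon would be the kind of neighbour that could begin to separate them, and how far compound 3 lies past its limit also stays open.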